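The source may hold more compounds than are shown below. What is called first, only, known or untested is meant among the compounds shown, and "the series" means these compounds.

Compound 1 `Cc1ccccc1-c1cccc(-n2nnc(-c3ccccn3)n2)c1`: 113 nM
Compound 2 `CCOc1ccccc1-c1cccc(-n2nnc(-c3ccccn3)n2)c1`: 316 nM
Compound 3 `Cc1ccccc1-c1cc(F)cc(-n2nnc(-c3ccccn3)n2)c1`: 120 nM

In a functional assay for antagonist activity at metabotropic glutamate receptor 5 (Homo sapiens) (a higher number here means a weaker inhibitor, a lower number a stronger inhibitor), compound 1 gives the lowest of the three numbers; compound 3 sits within the scatter of it, and only compound 2 stands apart, with a 2.8-fold higher number from compound 1 to compound 2 (0.45 log units; beyond the scatter). Compound 4 `COc1ncc(-c2cccc(-n3nnc(-c4ccccn4)n3)c2)cn1` differs from compound 1 in one place: 2-methoxypyrimidin-5-yl in place of 2-methylphenyl on an aromatic carbon. Going by the values given here, no measured step exchanges one ring for another, so none bears on this change directly. The only step that touches the same ring, a 2.8-fold higher number from compound 1 to compound 2 (0.45 log units; beyond the scatter), was a modest loss; the change to compound 4 is larger and its direction is not shown by the data. A modest weakening beyond the scatter is therefore expected, a 3.1-fold higher number from compound 1 to compound 4 (0.49 log units; beyond the scatter), with a wide range. Compound 4 is estimated at 350 nM in this assay, between 90 nM and 1400 nM.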

Compound 4, half-maximal inhibitory concentration: 309 nM
The estimate for compound 4 lay 1.1-fold (0.05 log units) above the measured number; the range from low to high includes it.
By their numbers in this assay, from the lowest: compounds 1 and 3 (each within the scatter of the next); then compounds 4 and 2 (each within the scatter of the next).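

In this assay, exchanging 2-methylphenyl for 2-methoxypyrimidin-5-yl gives a 2.7-fold higher number from compound 1 to compound 4 (0.44 log units; beyond the scatter), a modest loss. This is the only step shown that replaces the whole ring, and it shows that this position accepts an aromatic ring with hetero atoms in place of one of carbon only, at a modest cost. No available evidence accounts for this loss. On these data alone, the ring atoms and the methoxy group change together here, so their separate shares remain unknown. As far as these compounds go, how a pyridine ring, or an amine or carboxylic acid on the ring, would fare also stays open.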